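The compounds below may be only part of what the source reports. "The series", "measured", "known", "first", "only" and "open" are said of these compounds alone.

In a functional assay on MCF7 cells (Homo sapiens) for antiproliferative activity, tested at 1 uM (on this read-out higher numbers stand for more inhibition at the one concentration tested (going by the name of the read-out) and lower numbers for less inhibition), compound 1 `CCOC(=O)c1ccc(CO/N=C/c2c(C)nn(C)c2Oc2ccc(Cl)cc2)cc1` gives 33.9%, and compound 2 `Cc1nn(C)c(Oc2ccc(Cl)cc2)c1/C=N/OCc1ccc([N+](=O)[O-])cc1` gives 27.1%. On the two numbers shown compound 2 stands lower than compound 1, but the difference is within the usual scatter, so no real order between them is claimed. Within the data shown here, the single measured step, a number 6.8 percentage points lower from compound 1 to compound 2 (within the scatter), is the only guide. Compound 3 `COC(=O)c1ccc(CO/N=C/c2c(C)nn(C)c2Oc2ccc(Cl)cc2)cc1` differs from compound 2 by methoxycarbonyl in place of nitro on an aromatic carbon. Because the earlier exchange a number 6.8 percentage points lower from compound 1 to compound 2 (within the scatter) stayed within the scatter, compound 3 is expected to sit close to both, with a step of a number 4.9 percentage points higher from compound 2 to compound 3 (within the scatter). Compound 3 is therefore estimated at 32%, between 20% and 44%.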

Compound 3, a percentage reported as inhibition, at one concentration (the size of the read-out at that concentration, not a potency): 33.6%
Compound 3: middle estimate off by 1.6 percentage points, on the low side; the range from low to high includes it.
By their numbers in this assay, from the lowest: compounds 2, 3 and 1 (each within the scatter of the next).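

In this assay, methoxycarbonyl in place of nitro on the aromatic carbon para to a large group gives a number 6.5 percentage points higher from compound 2 to compound 3 (within the scatter), so this exchange leaves the reading within the scatter. The ester chain adds a second such result: hydrogen in place of methyl on the saturated chain carbon gives a number 0.3 percentage points lower from compound 1 to compound 3 (within the scatter), and ethoxycarbonyl and methoxycarbonyl cannot be told apart. Nothing available explains these readings. As far as these compounds go, it remains open whether a carboxylic acid or an amine at this position would give a reading beyond the scatter from these three compounds.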